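Swapping the hydroxy-ether chain for an ester chain

A few compounds are considered here, and "the series" means these few. Any claim that something is new, unique, unknown or untested is made for them only; others in the source may bear on it.

Compounds measured in an assay (Cricetulus griseus) for inhibition of aldehyde dehydrogenase, mitochondrial (Homo sapiens); a lower number here means a stronger inhibitor, a higher number a weaker inhibitor:
compound 1 `O=c1c(-c2ccc(O)cc2)coc2cc(OCCOCCOCCO)ccc12` gives 40 nM
compound 2 `CCCCCCOc1ccc2c(=O)c(-c3ccc(O)cc3)coc2c1` gives 1500 nM
compound 3 `O=c1c(-c2ccc(O)cc2)coc2cc(OCCCCCCCCCO)ccc12` gives 700 nM

Compound 1 has the lowest number of the three, so it is the strongest inhibitor among them. Compound 4 `CCOC(=O)CCCCOc1ccc2c(=O)c(-c3ccc(O)cc3)coc2c1` differs from it in one place: 2-(ethoxycarbonyl)ethyl in place of 2-(2-hydroxyethoxy)ethoxy on a saturated chain carbon, two bonds along the chain from an oxygen on an aromatic ring. Two measured steps start from the same position on compound 1. Replacing the chain gave a 38-fold higher number from compound 1 to compound 2 (1.57 log units; beyond the scatter) and an 18-fold higher number from compound 1 to compound 3 (1.24 log units; beyond the scatter), both large rises. Compound 4 likewise loses the 2-(2-hydroxyethoxy)ethoxy chain, so a large rise of the same kind is expected in this assay, with a 20-fold higher number from compound 1 to compound 4 (1.30 log units; beyond the scatter). Compound 4 is therefore estimated at 800 nM, within 200 nM to 3000 nM.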

Compound 4, half-maximal inhibitory concentration: 240 nM
The estimate for compound 4 lay 3.3-fold (0.52 log units) above the measured number, and the stated range covers the measured number.
By their numbers in this assay, from the lowest: compound 1; then compound 4; then compound 3; then compound 2.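

In this assay, within the data shown here, an ethoxycarbonyl-ended chain is the first replacement at this position to cost only a modest rise, with a 6.0-fold higher number from compound 1 to compound 4 (0.78 log units; beyond the scatter) against the large rises seen earlier. It also gives a stronger inhibitor than either other replacement, with a 2.9-fold lower number from compound 3 to compound 4 (0.46 log units; beyond the scatter) and a 6.3-fold lower number from compound 2 to compound 4 (0.80 log units; beyond the scatter) at this same position. Nothing shown here explains why this chain end fares better.

Still open, going by these compounds, is whether a carboxylic acid or an amide at the chain end would match compound 4. Also open, on these data alone, is how a shorter or longer chain carrying the same ester would behave.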